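A few compounds are considered here, and "the series" means these few. Any claim that something is new, unique, unknown or untested is made for them only; others in the source may bear on it.

Compound 1 `O=C1O/C(=C\Cn2cc(-c3ccc(Br)cc3)nn2)C(OCc2ccccc2)=C1OCc1ccccc1` gives in a functional assay on HCT-116 cells (Homo sapiens) for antiproliferative activity, read by MTT assay, with a stated time of 72 h (a higher number here means a weaker inhibitor, a lower number a stronger inhibitor), only a limit, > 100000 nM.
Compound 2 `O=C1O[C@H]([C@@H](O)Cn2cc(-c3cccc(O)c3)nn2)C(OCc2ccccc2)=C1OCc1ccccc1` gives 42900 nM.
Compound 3 `CCCCc1cn(C[C@H](O)[C@H]2OC(=O)C(OCc3ccccc3)=C2OCc2ccccc2)nn1` gives 10400 nM.

Compound 1 thus stands at the limit of the assay, (the limit of > 100000 nM in this assay, at which 1 of the 3 values shown sits), while the other two give numbers, and compound 3 gives the lower one. Compound 4 `O=C1O/C(=C\Cn2cc(-c3cccc(O)c3)nn2)C(OCc2ccccc2)=C1OCc1ccccc1` differs from compound 1 by 3-hydroxyphenyl in place of 4-bromophenyl on an aromatic carbon. Going by the values given here, no measured step shares this change: the only step, a 4.1-fold lower number from compound 2 to compound 3 (0.62 log units; beyond the scatter), exchanges a 3-hydroxyphenyl for a butyl on a saturated, hydroxylated core. Among the compounds with values here, the 3-hydroxyphenyl that enters compound 4 is the one carried by compound 2, which gives 42900 nM, a weak value. Compound 4 is therefore expected to remain weak, with a number no higher from compound 1 to compound 4 (the limit leaves the size open) not clearly beyond the scatter and possibly again only a limit. The estimate for compound 4 is 100000 nM, between 30000 nM and 300000 nM.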

Compound 4, half-maximal inhibitory concentration: 63600 nM
Estimate against measurement, compound 4: 1.6-fold (0.20 log units) above, and the stated range covers the measured number.
By their numbers in this assay, from the lowest: compound 3; then compounds 2 and 4 (each within the scatter of the next). At a limit, above all of these: compound 1.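

Going by these compounds alone, with 3-hydroxyphenyl in place of 4-bromophenyl on the aromatic carbon of the five-membered ring, the unsaturated series gives a measured number in this assay for the first time (an at least 1.5-fold lower number from compound 1 to compound 4 (0.19 log units; that floor lies within the scatter)). That floor does not show a change beyond the scatter. Going by these compounds, the true size of the step stays unknown, as compound 1 gives only a limit: the limit of > 100000 nM in this assay, at which 1 of the 4 values shown sits.

The compounds shown leave open whether an amine or a carboxylic acid on the phenyl ring would lower the number. They also leave open how a longer chain would behave at this position.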